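A few compounds are considered here, and "the series" means these few. Any claim that something is new, unique, unknown or untested is made for them only; others in the source may bear on it.

Compound 1, whose structure is `C=C(C)[C@@H]1CC=C(Cn2cc(COc3ccc(C4NC(=O)NC(C)=C4C(=O)OCC)cc3)nn2)CC1`, gives 97100 nM in a functional assay on 786-0 cells (Homo sapiens) for inhibition, read by sulforhodamine B assay, with a stated time of 48 h; a lower number here means a stronger inhibitor of growth, a higher number a weaker inhibitor of growth. Compound 2, with the structure `C=C(C)[C@@H]1CC=C(Cn2cc(COc3ccc(C4NC(=O)NC(C)=C4C(=O)OCC)cc3OC)nn2)CC1`, differs from compound 1 by methoxy in place of hydrogen on an aromatic carbon; in this assay compound 2 gives 87300 nM, and the step is a 1.1-fold lower number from compound 1 to compound 2 (0.05 log units; within the scatter). Compound 3 has the structure `C=C(C)[C@@H]1CC=C(Cn2cc(COc3ccc(C4NC(=O)NC5=C4C(=O)CC(C)(C)C5)cc3)nn2)CC1` and a different core; the difference between the two cores is not broken down here. In this assay compound 3 gives 53200 nM. Compound 4, with the structure `C=C(C)[C@@H]1CC=C(Cn2cc(COc3ccc(C4NC(=O)NC5=C4C(=O)CC(C)(C)C5)cc3OC)nn2)CC1`, differs from compound 3 by methoxy in place of hydrogen on an aromatic carbon, the same change as that from compound 1 to compound 2, made at a place described in the same words; it occurs twice among these compounds. The expected step is a 1.1-fold lower number from compound 3 to compound 4 (0.04 log units; within the scatter), because the earlier step was a 1.1-fold lower number from compound 1 to compound 2 (0.05 log units; within the scatter). Compound 4 is thus estimated to give 48000 nM, expected between 24000 nM and 96000 nM.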

Compound 4, concentration for total growth inhibition: > 100000 nM
Compound 4 was reported as a limit; the forecaster's own chance of this, stated with the estimate: 10%; at least 2.0-fold (0.31 log units) between middle value and limit.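

In this assay compound 4 gives > 100000 nM, which is a limit of the assay and not an exact number. As far as these compounds go, the methoxy step on this second core is an at least 1.8-fold higher number from compound 3 to compound 4 (0.27 log units; that floor lies within the scatter), so only a floor is known and the real size of the step stays unknown. Set side by side, the two steps show neither that the change carries over from one core to the other nor that it fails to: the same change on two cores in this assay, a 1.1-fold lower number (0.05 log units; within the scatter) from compound 1 to compound 2 and an at least 1.8-fold higher number (0.27 log units; that floor lies within the scatter) from compound 3 to compound 4; the limit leaves it open whether they differ

From the compounds shown here alone, only hydrogen and methoxy appear at this place on the aromatic ring, so what an amine or a longer chain such as ethoxy would do there on either core remains open. Going by these compounds, whether methoxy would give a similar step on a third core is also open.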